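Swapping nitro for bromo on the benzylsulfanyl arm

This account rests on a few compounds, and the source may have more. Where it says the series, first, only, none or still open, it means among the compounds named here.

Compound 1 `Cc1cc(Nc2cc(-c3ccccc3)[nH]n2)n2nc(SCc3ccc([N+](=O)[O-])cc3)nc2n1` is the (4-nitrobenzyl)sulfanyl member of a small set built on one shared core. In a functional assay on PC-9 cells (Homo sapiens) for inhibition, read by MTT assay, with a stated time of 72 h (a lower number here means a stronger inhibitor, a higher number a weaker inhibitor), compound 1 gives 7980 nM, the highest of the three numbers, though each of the other two sits within the scatter of it. Compound 2 `Cc1cc(Nc2cc(-c3ccccc3)[nH]n2)n2nc(SCc3c(Cl)cccc3Cl)nc2n1` gives 5180 nM and compound 3 `Cc1cc(Nc2cc(-c3ccccc3)[nH]n2)n2nc(SCc3ccc(C(F)(F)F)cc3)nc2n1` gives 4240 nM. The steps of a 1.5-fold lower number from compound 1 to compound 2 (0.19 log units; within the scatter) and a 1.9-fold lower number from compound 1 to compound 3 (0.27 log units; within the scatter) show that changing the group on this aromatic ring has moved the number little so far. Compound 4 `Cc1cc(Nc2cc(-c3ccccc3)[nH]n2)n2nc(SCc3ccc(Br)cc3)nc2n1` differs from compound 1 by bromo in place of nitro on an aromatic carbon. This change most resembles the one measured as a 1.9-fold lower number from compound 1 to compound 3 (0.27 log units; within the scatter), so the step of a 1.5-fold lower number from compound 1 to compound 4 (0.16 log units; within the scatter) is expected to stay within the scatter as well. Compound 4 is therefore estimated at 5500 nM, with a range from 2500 nM to 12000 nM.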

Compound 4, half-maximal inhibitory concentration: 4760 nM
Estimate against measurement, compound 4: 1.2-fold (0.06 log units) above; low and high end bracket the measured number.
By their numbers in this assay, from the lowest: compounds 3, 4, 2 and 1 (each within the scatter of the next).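

Bromo brings one heavy atom and no hydrogen-bond acceptors where nitro had three heavy atoms and two acceptors, and in this assay this gives a 1.7-fold lower number from compound 1 to compound 4 (0.22 log units; within the scatter) and stays within the scatter. Against the other arms, the result is a 1.1-fold higher number from compound 3 to compound 4 (0.05 log units; within the scatter) and a 1.1-fold lower number from compound 2 to compound 4 (0.04 log units; within the scatter) and neither step leaves the scatter, so all four arms remain indistinguishable in this assay. Nothing available explains this flat picture. The compounds shown leave open whether an amine or a carboxylic acid at this ring position would move the number beyond the scatter. As far as these compounds go, a longer chain between the sulfur and the ring also remains open.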